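Methyl on the oxygen in the chloro-bearing series

This account rests on a few compounds, and the source may have more. Where it says the series, first, only, none or still open, it means among the compounds named here.

Measured so far:
compound 1 `COc1cc(/C=C/c2nc3cccnc3n(CC(=O)O)c2=O)ccc1O`: 48.6%
compound 2 `O=C(O)Cn1c(=O)c(/C=C/c2ccc(O)c(O)c2)nc2cc(Cl)cnc21`: 74.7%
compound 3 `O=C(O)Cn1c(=O)c(-c2ccccc2)nc2cccnc21`: "not determined" (no result reported)

In a functional assay, read by spectrophotometry, with a stated time of 30 min, tested at 10 uM (a lower number here means a weaker effect, a higher number a stronger effect of the compound at the concentration tested), compound 2 gives 74.7%, the higher of the two numbers recorded; in the same assay compound 1 gives 48.6%, a number that lies beyond the usual scatter below it. In this assay compound 3 gives "not determined" (no result reported). Compound 4 `COc1cc(/C=C/c2nc3cc(Cl)cnc3n(CC(=O)O)c2=O)ccc1O` differs from compound 2 in one place: methyl in place of hydrogen on an oxygen on an aromatic ring. Among the compounds with values here, no two measured compounds differ in only one place, so the size of this step is not fixed by the data; compound 1, which carries the 4-hydroxy-3-methoxyphenyl group, gives the lower of the two numbers, though it differs from compound 2 in a second place as well. The expected step is a number 16.7 percentage points lower from compound 2 to compound 4 (beyond the scatter), a downward one of about the size of the scatter or a little beyond it. Compound 4 is estimated at 58%, within 38% to 78%.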

Compound 4, a percentage reported as activity, at one concentration (the size of the read-out at that concentration, not a potency): 62.3%
Compound 4: middle estimate off by 4.3 percentage points, on the low side; low and high end bracket the measured number.
By their numbers in this assay, from the lowest: compound 1; then compound 4; then compound 2.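

In this assay methyl in place of hydrogen on an oxygen on an aromatic ring now has a measured size with chloro present: a number 12.4 percentage points lower from compound 2 to compound 4 (beyond the scatter) is a modest drop. With the 4-hydroxy-3-methoxyphenyl group held constant, chloro in place of hydrogen on an aromatic carbon gives a number 13.7 percentage points higher from compound 1 to compound 4 (beyond the scatter) and so a modest gain. No available data explain either step.

As far as these compounds go, whether the methyl step has the same size without chloro remains open. So does the effect of ethyl on that oxygen, or of an amine in place of chloro.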